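The compounds below may be only part of what the source reports. "The series", "measured", "known", "first", "only" and "open" are said of these compounds alone.

Compound 1 `COc1ccc(S(=O)(=O)c2cnc3ccc(OC)cc3c2N2CCC(C)CC2)cc1` — 41%
Compound 2 `COc1ccc2ncc(S(=O)(=O)c3ccc(OC)c(Cl)c3)c(N3CCC(C)CC3)c2c1` — 21%
Compound 3 `COc1ccc2ncc(S(=O)(=O)c3ccc(C)c(F)c3)c(N3CCC(C)CC3)c2c1` — 73%

All three numbers come from an assay on isolated protein for displacement of a labelled ligand from metabotropic glutamate receptor 5 (Homo sapiens), with a stated time of 60 min, tested at 1 uM; a higher number here means more inhibition at the concentration tested (going by the name of the read-out), a lower number less inhibition. Compound 3 stands highest of the three: a number 32 percentage points higher from compound 1 to compound 3 (beyond the scatter) and a number 52 percentage points higher from compound 2 to compound 3 (beyond the scatter), both beyond the scatter. Compound 4 `COc1ccc2ncc(S(=O)(=O)c3cc(Cl)cc(Cl)c3)c(N3CCC(C)CC3)c2c1` is not yet measured and differs from compound 3 in one place: 3,5-dichlorophenyl in place of 3-fluoro-4-methylphenyl on a sulfonyl sulfur. Going by the values given here, the steps that bear on this are the two that change the group on the sulfonyl sulfur, a number 32 percentage points higher from compound 1 to compound 3 (beyond the scatter) and a number 52 percentage points higher from compound 2 to compound 3 (beyond the scatter), and the chloro introduction a number 20 percentage points lower from compound 1 to compound 2 (beyond the scatter). The other two sulfonyl aryl groups seen give far lower numbers than the 3-fluoro-4-methylphenyl group of compound 3, and the single chloro addition lowered the number. Among the compounds with values here, a downward step beyond the scatter is therefore expected, a number 28 percentage points lower from compound 3 to compound 4 (beyond the scatter), though no measured pair carries a 3,5-dichlorophenyl group. Compound 4 is estimated at 45%, in the range 20% to 72%.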

Compound 4, a percentage reported as inhibition, at one concentration (the size of the read-out at that concentration, not a potency): 87%
Beside the measured number, compound 4's estimate is 42 percentage points below it; the measured number lies above the stated range.
By their numbers in this assay, from the lowest: compound 2; then compound 1; then compound 3; then compound 4.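

On the sulfonyl sulfur, 3,5-dichlorophenyl gives the highest number of the four in this assay, over 3-fluoro-4-methylphenyl (a number 14 percentage points higher from compound 3 to compound 4 (beyond the scatter)), 4-methoxyphenyl (a number 46 percentage points higher from compound 1 to compound 4 (beyond the scatter)) and 3-chloro-4-methoxyphenyl (a number 66 percentage points higher from compound 2 to compound 4 (beyond the scatter)). Chloro on this aryl group therefore does not go with a lower number in every case: compound 2 goes down, compound 4 goes up. No measurement here accounts for this order.

Going by these compounds, whether the gain needs both chloro groups stays open, and 3,5-difluorophenyl or 3-chlorophenyl would bear on that. So does a morpholine on the sulfonyl sulfur, for whether an aryl group is needed at all.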